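The source may hold more compounds than are shown below. What is called first, only, known or untested is meant among the compounds shown, and "the series" means these compounds.

Working notes on the series: in a functional assay on MDA-MB-231 cells (Homo sapiens) for antiproliferative activity, read by CCK-8 assay, with a stated time of 72 h (a higher number here means a weaker inhibitor, a lower number a stronger inhibitor), compound 1 (`Cc1cc(Nc2cc(N3CCN(C)CC3)nc(Nc3ccc(S(N)(=O)=O)cc3)n2)n[nH]1`) gives 1210 nM, the higher of the two numbers so far, and compound 2 (`Cc1cc(Nc2cc(N3CCN(C)CC3)nc(Nc3ccc([N+](=O)[O-])cc3)n2)n[nH]1`) gives 84.4 nM. Compound 3 (`Cc1cc(Nc2cc(N3CCN(C)CC3)nc(Nc3cccc(Cl)c3)n2)n[nH]1`) differs from compound 1 by 3-chlorophenyl in place of 4-sulfamoylphenyl on a nitrogen on an aromatic ring. For the measured compounds named here, only one measured step bears on this change: nitro in place of sulfamoyl gave a 14-fold lower number from compound 1 to compound 2 (1.16 log units; beyond the scatter), so sulfamoyl also departs there. On that single step, a lower number is expected in this assay, probably by less than that step. The expected step is a 4.8-fold lower number from compound 1 to compound 3 (0.68 log units; beyond the scatter). Compound 3 is estimated at 250 nM, with an expected range of 60 nM to 1000 nM.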

Compound 3, half-maximal inhibitory concentration: 56.4 nM
Estimate against measurement, compound 3: 4.4-fold (0.65 log units) above; measured number outside the range, below it.
By their numbers in this assay, from the lowest: compounds 3 and 2 (each within the scatter of the next); then compound 1.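

In this assay, 3-chlorophenyl in place of 4-sulfamoylphenyl gives a 21-fold lower number from compound 1 to compound 3 (1.33 log units; beyond the scatter), so a second, quite different group on this nitrogen also departs from the high number of compound 1. Between the two replacements, the data give a 1.5-fold lower number from compound 2 to compound 3 (0.18 log units; within the scatter), leaving 4-sulfamoylphenyl alone apart among these three groups. No measurement at hand gives a cause for this.

The step to compound 3 changes both the substituent and its place on the ring, and these remain unseparated. Plain phenyl or 4-chlorophenyl would bear on that, and an amine or a carboxylic acid on the ring remains open.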